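A few compounds are considered here, and "the series" means these few. Any claim that something is new, unique, unknown or untested is made for them only; others in the source may bear on it.

Compound 1 `C/C(=N/NC(=O)c1ccc(S(N)(=O)=O)cc1)c1ccc(Cl)cc1` is tested in a functional assay on MCF7 cells (Homo sapiens) for antiproliferative activity, read by MTT assay (a lower number here means a stronger inhibitor, a higher number a weaker inhibitor), where compound 1 gives 3750 nM. Compound 2 `C/C(=N/NC(=O)c1ccc(S(N)(=O)=O)cc1)c1ccc(F)cc1` differs from it in one spot, (fluoro in place of chloro on an aromatic carbon), and in this assay compound 2 gives 31900 nM; that single exchange made a step of an 8.5-fold higher number from compound 1 to compound 2 (0.93 log units; beyond the scatter). Compound 3 `NS(=O)(=O)c1ccc(C(=O)N/N=C\c2ccc(Cl)cc2)cc1` is built on a different core, and how the two cores differ is not broken down here. In this assay compound 3 gives 36700 nM. Compound 4 `NS(=O)(=O)c1ccc(C(=O)N/N=C\c2ccc(F)cc2)cc1` has not yet been measured; it differs from compound 3 by fluoro in place of chloro on an aromatic carbon, at the same place as before, so this is the same change. Compound 4 is therefore expected to be weaker than compound 3 by about a 2.7-fold higher number from compound 3 to compound 4 (0.44 log units; beyond the scatter), resting on an 8.5-fold higher number from compound 1 to compound 2 (0.93 log units; beyond the scatter), while allowing that a different core need not repeat that step exactly. Compound 4 is estimated to give about 100000 nM in this assay, most likely between 35000 nM and 350000 nM.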

Compound 4, half-maximal inhibitory concentration: 9170 nM
For compound 4 the middle estimate is 11-fold (1.04 log units) above the measured one, and the stated range ends above it.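

In this assay, fluoro in place of chloro on the aromatic ring gives a 4.0-fold lower number from compound 3 to compound 4 (0.60 log units; beyond the scatter), so on this core the exchange strengthens the compound, while on the core of compound 1 the same exchange weakens it. The change therefore does not carry over from one core to the other, not even in direction: the same change on two cores in this assay, an 8.5-fold higher number (0.93 log units; beyond the scatter) from compound 1 to compound 2 and a 4.0-fold lower number (0.60 log units; beyond the scatter) from compound 3 to compound 4, 34-fold (1.53 log units) apart, beyond the scatter of two such steps. Within the data shown here, this does not show why the direction reverses, and with only one pair on each core it gives no rule for any further core.

As far as these compounds go, what stays open is how a methoxy group or an amine at this place would behave on each core. From the compounds shown here alone, whether a third core would follow either pair also remains unknown.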